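Capping the Amine: From Compound 2 to Compound 3

The source may hold more compounds than are shown below. What is called first, only, known or untested is meant among the compounds shown, and "the series" means these compounds.

Compound 1, `CCCCCC(=O)OCc1ccc2oc(=O)c(C(=O)Oc3cccc(Br)c3)cc2c1`: 33.9%
Compound 2, `NCc1ccc2oc(=O)c(C(=O)Oc3cccc(Br)c3)cc2c1`: 63.6%

In a functional assay on HT-1080 cells (Homo sapiens), read by transwell migration, with a stated time of 24 h, tested at 10 uM (on this read-out lower numbers stand for a stronger effect and higher numbers for a weaker effect at the one concentration tested), compound 2 gives 63.6%, the highest of the two numbers, while compound 1 gives 33.9%. Among the compounds with values here, the one known step is a number 29.7 percentage points higher from compound 1 to compound 2 (beyond the scatter). Compound 3, `CC(=O)NCc1ccc2oc(=O)c(C(=O)Oc3cccc(Br)c3)cc2c1`, differs from compound 2 by acetyl in place of hydrogen on an amine nitrogen. That step bears on the change only loosely, since compound 1 carries a (pentylcarbonyl)oxy group rather than an acetamido group and sits at 33.9%. Compound 3 is therefore expected to give 50% (range 30% to 70%), an expected step of a number 13.6 percentage points lower from compound 2 to compound 3 (beyond the scatter).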

Compound 3, a percentage reported as activity, at one concentration (the size of the read-out at that concentration, not a potency): 27.1%
Beside the measured number, compound 3's estimate is 22.9 percentage points above it, outside the stated range (below it).
By their numbers in this assay, from the lowest: compounds 3 and 1 (each within the scatter of the next); then compound 2.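

Putting acetyl on the amine nitrogen gives a number 36.5 percentage points lower from compound 2 to compound 3 (beyond the scatter) in this assay and so ties the weaker effect of compound 2 to the free amino group, not to the saturated chain carbon that carries it. With acetamido in place of (pentylcarbonyl)oxy, the same read-out shows a number 6.8 percentage points lower from compound 1 to compound 3 (within the scatter) and so this position accepts either group with no difference beyond the scatter. Nothing measured here explains these results.

On these data alone, it remains open whether a longer chain on the carbonyl, such as hexanoyl, would match acetyl. A sulfonamide or a urea on the same nitrogen is equally untested among these compounds.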